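This account rests on a few compounds, and the source may have more. Where it says the series, first, only, none or still open, it means among the compounds named here.

In a functional assay on MCF7 cells (Homo sapiens) for inhibition, read by MTT assay, with a stated time of 72 h (on this read-out lower numbers stand for stronger inhibition and higher numbers for weaker inhibition), compound 1 `O=C(Nc1ccccc1)C1CCN(C/C=C/c2ccccc2)CC1` gives 60200 nM and compound 2 `CCCCc1ccc(NC(=O)C2CCN(C/C=C/c3ccccc3)CC2)cc1` gives 5870 nM, the lower of the two numbers in the series. Compound 3 `COc1ccccc1NC(=O)C1CCN(C/C=C/c2ccccc2)CC1` reads > 100000 nM, which is a limit of the assay and not a number.

Butyl in place of hydrogen on an aromatic carbon gave a 10-fold lower number from compound 1 to compound 2 (1.01 log units; beyond the scatter). Adding a methoxy group instead gave an at least 1.6-fold higher number from compound 1 to compound 3 (0.22 log units; that floor lies within the scatter), and that floor lies within the scatter.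

Compound 4 `CN1CCN(c2ccc(NC(=O)C3CCN(C/C=C/c4ccccc4)CC3)cc2)CC1` has 4-methylpiperazin-1-yl in place of butyl on an aromatic carbon, para to a large group: 4-methylpiperazin-1-yl in place of butyl on an aromatic carbon. Going by the values given here, no measured step tests this group directly. The step that bears most closely is the large 10-fold lower number from compound 1 to compound 2 (1.01 log units; beyond the scatter), as it introduced the butyl that now leaves. Part of that gain may be given back, so a moderate move to a higher number is expected in this assay.

The expected step is a 2.6-fold higher number from compound 2 to compound 4 (0.41 log units; beyond the scatter). For compound 4 the estimated value is 15000 nM, with an expected range of 4000 nM to 60000 nM.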

Compound 4, half-maximal inhibitory concentration: 44000 nM
Compound 4: middle estimate off by 2.9-fold (0.47 log units), on the low side, and the stated range covers the measured number.
By their numbers in this assay, from the lowest: compound 2; then compounds 4 and 1 (each within the scatter of the next). At a limit, above all of these: compound 3.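

In this assay, at this aromatic carbon para to a large group, 4-methylpiperazin-1-yl in place of butyl gave a 7.5-fold higher number from compound 2 to compound 4 (0.87 log units; beyond the scatter), so the gain seen with butyl does not extend to every large group at this place. Against hydrogen, the same group gave a 1.4-fold lower number from compound 1 to compound 4 (0.14 log units; within the scatter); compound 4 and compound 1 cannot be told apart here, so a six-membered non-aromatic ring with 2 hetero atoms at this place brings no measurable gain over hydrogen. Nothing shown gives a cause for the loss from butyl to 4-methylpiperazin-1-yl.

Open, on these data alone, is whether the lower number of compound 2 depends on the open chain or on a substituent of carbon only. A hexyl chain or a cyclohexyl ring at this same place would begin to separate those two readings.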